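A few compounds are considered here, and "the series" means these few. Any claim that something is new, unique, unknown or untested is made for them only; others in the source may bear on it.

Measured so far:
compound 1 `COc1ccccc1C(=O)NC(=O)Nc1ccc(-c2ccccc2)c(C(F)(F)F)c1` — 15 mL.min-1.g-1 in an in vitro ADME assay on microsomes from liver (Rattus norvegicus) for metabolic stability, with a stated time of 30 min; a higher number here means faster removal of the compound, a lower number slower removal
compound 2 `COc1ccccc1C(=O)NC(=O)Nc1ccc(-c2ccccn2)c(C(F)(F)F)c1` — 15 mL.min-1.g-1 in this assay

For the measured compounds named here, compound 1 stands level with compound 2; the only measured step, no change at the digits printed from compound 1 to compound 2 (within the scatter), is within the scatter. Compound 3 `COc1ccccc1C(=O)NC(=O)Nc1ccc(C(C)C)c(C(F)(F)F)c1` carries the change (isopropyl in place of phenyl on an aromatic carbon). Going by the values given here, no measured step touches this change: the one step at hand swaps one aromatic ring for another and leaves the value unmoved, so it gives no lead on direction. The expectation is therefore no step beyond the scatter, a 1.2-fold higher number from compound 1 to compound 3 (0.08 log units; within the scatter), with a wide range. For compound 3 in this assay the estimate is 18 mL.min-1.g-1, between 7 mL.min-1.g-1 and 45 mL.min-1.g-1.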

Compound 3, intrinsic clearance in microsomes: < 14 mL.min-1.g-1
Compound 3 ended at the assay's limit; the forecaster's own chance of this, stated with the estimate: 5%; middle value at least 1.2-fold (0.10 log units) away from the limit.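

Compound 3 carries a limit of the assay, not a number, in this assay: the limit of < 14 mL.min-1.g-1 in this assay, at which 1 of the 3 values shown sits.

Isopropyl, which has no ring, gives an at least 1.0-fold lower number from compound 1 to compound 3 (0.02 log units; that floor lies within the scatter), and an at least 1.0-fold lower number from compound 2 to compound 3 (0.02 log units; that floor lies within the scatter). Unlike the swap of one aromatic ring for another, this shows that an aromatic ring on this carbon is not needed to keep the number from rising, though the true size of any drop stays unknown.

Open, from the compounds shown here alone, is how a cyclohexyl group, a morpholine or a carboxylic acid on this aromatic carbon would read in this assay.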